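Chloro for Methoxy on the Chain-End Ring

A few compounds are considered here, and "the series" means these few. Any claim that something is new, unique, unknown or untested is made for them only; others in the source may bear on it.

Compound 1, `O=C(/C=C/c1ccc(Br)cc1)c1cccc(-c2cccc(F)c2)c1`, in an assay on A549 cells for inhibition of transcription factor p65 (Homo sapiens), read by fluorescence, with a stated time of 2 h (a higher number here means a weaker inhibitor, a lower number a stronger inhibitor), gives > 50000 nM, which is a limit of the assay rather than a number.
Compound 2, `O=C(/C=C/c1cccc(Br)c1)c1cccc(-c2cccc(F)c2)c1`, in this assay gives 11200 nM.
Compound 3, `COc1ccc(/C=C/C(=O)c2cccc(-c3cccc(F)c3)c2)cc1`, in this assay gives > 50000 nM, again a limit of the assay.

Compound 3 thus stands at the limit: its value is one of the two that sit at the limit of > 50000 nM in this assay, at which 2 of the 3 values shown sit, and only compound 2 has a readable number. The change to compound 4, `O=C(/C=C/c1ccc(Cl)cc1)c1cccc(-c2cccc(F)c2)c1`, is chloro in place of methoxy on an aromatic carbon. The step of an at least 4.4-fold higher number from compound 2 to compound 3 (0.64 log units; beyond the scatter) shows that going from the readable compound 2 to the 4-methoxyphenyl group loses potency. The step of an at least 4.4-fold lower number from compound 1 to compound 2 (0.64 log units; beyond the scatter) shows that compound 1, whose 4-bromophenyl group is the halogen counterpart of the new 4-chlorophenyl group, also sits at the limit, and the step that the two limits leave unreadable from compound 1 to compound 3 is not readable, both of its ends being limits. Compound 4 carries a halogen on that ring as compound 1 does and is expected to stay at or near the limit. The expected step is a number no higher from compound 3 to compound 4 (the limit leaves the size open). Compound 4 is estimated at 50000 nM, with a range from 15000 nM to 150000 nM.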

Compound 4, half-maximal inhibitory concentration: 24400 nM
The estimate for compound 4 lay 2.0-fold (0.31 log units) above the measured number; measured number inside the range.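

Putting chloro in place of methoxy at this ring position, para to a large group, brings a readable number in this assay, as an at least 2.0-fold lower number from compound 3 to compound 4 (0.31 log units; beyond the scatter) shows, so a group at this position need not leave a compound at the limit. The choice of halogen matters here too, since exchanging bromo for chloro at the same place gives an at least 2.0-fold lower number from compound 1 to compound 4 (0.31 log units; beyond the scatter), and the two halogens therefore do not behave alike on this ring. Even so, the 4-chlorophenyl group does not fully match the 3-bromophenyl group, with a 2.2-fold higher number from compound 2 to compound 4 (0.34 log units; beyond the scatter), although that comparison changes both the halogen and its place on the ring, so it cannot say which of the two counts.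

On these data alone, compound 1 and compound 3 remain limits of the assay rather than numbers, so the true size of the gain from either one to the chloro compound stays unknown: the limit of > 50000 nM in this assay, at which 2 of the 4 values shown sit. How a 3-chlorophenyl group would compare with the 3-bromophenyl group, and whether an amine or a carboxylic acid at the chain-end ring would give a readable number, stays open.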